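This account rests on a few compounds, and the source may have more. Where it says the series, first, only, none or still open, it means among the compounds named here.

Two compounds share one core. Compound 1 `Clc1cccc(Nc2ccc(N3CC4CC(C3)N4)nn2)c1` gives 1540 nM in an assay on cell membranes for displacement of a labelled ligand from Neuronal acetylcholine receptor; alpha4/beta2 (Rattus norvegicus); on this read-out lower numbers stand for stronger inhibition and higher numbers for weaker inhibition; compound 2 `Fc1ccc(Nc2ccc(N3CC4CC(C3)N4)nn2)cc1` gives 868 nM. The step of a 1.8-fold lower number from compound 1 to compound 2 (0.25 log units; within the scatter) is within the scatter, so compound 2 stands at the lower of the two numbers without separating from compound 1. Compound 3 `O=[N+]([O-])c1ccc(Nc2ccc(N3CC4CC(C3)N4)nn2)cc1` differs from compound 2 by nitro in place of fluoro on an aromatic carbon. Among the compounds with values here, no measured step swaps a substituent on this ring for a nitro group, so the single step from compound 1 to compound 2 is only weak guidance; no step beyond the scatter is expected in this assay. Compound 3 is therefore estimated at 750 nM, range 200 nM to 2800 nM, an expected step of a 1.2-fold lower number from compound 2 to compound 3 (0.06 log units; within the scatter).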

Compound 3, inhibition constant: 86.2 nM
Compound 3: middle estimate off by 8.7-fold (0.94 log units), on the high side; measured number below the stated range.
By their numbers in this assay, from the lowest: compound 3; then compounds 2 and 1 (each within the scatter of the next).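

Within the data shown here, at this aromatic carbon, para to a large group, nitro in place of fluoro gives a 10-fold lower number from compound 2 to compound 3 (1.00 log units; beyond the scatter) in this assay, the first step beyond the scatter. The substituent at this position can therefore shift the read-out clearly, which compound 1 and compound 2 did not show, as their values stayed within the scatter of each other. No measurement at hand bears on what lies behind this step. Going by these compounds, whether the lower number is particular to nitro remains open. A nitrile, an amine or a carboxylic acid on the same carbon would test that.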